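A Chloroacetamide Substituent on a Shared Core Against the Limit

The source may report more compounds than this note shows. Statements on the series, on what has been measured and on what is new or still open speak of the compounds shown alone.

Compound 1 `O=c1[nH]c(=O)n(COC(CO)CO)cc1O` is one of three compounds tested in a functional assay on NCI-H460 cells (Homo sapiens) for inhibition, read by MTT assay, with a stated time of 72 h; a higher number here means a weaker inhibitor, a lower number a stronger inhibitor. In this assay compound 1 reaches only the limit of > 100000 nM, not a number. Compound 2 `CC(C)(C)OC(=O)NCCNCC(=O)Nc1c[nH]c(=O)[nH]c1=O` likewise gives the limit > 100000 nM. Compound 3 `Cc1cc(=O)[nH]c(=O)n1COC(CO)CO` also stops at the limit > 100000 nM. For the measured compounds named here, compound 1 therefore stands where every value so far stands, namely at the limit of > 100000 nM in this assay, at which 3 of the 3 values shown sit. Going by the values given here, no step between measured compounds can be drawn, since none of them yields a number.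

Compound 4 `O=C(CCl)Nc1cn(COC(CO)CO)c(=O)[nH]c1=O` differs from compound 1 in one place: ((chloromethyl)carbonyl)amino in place of hydroxy on an aromatic carbon. With every measured value sitting at the limit, nothing in the data shows whether such a change moves potency in either direction, and no step beyond the scatter can be expected in this assay on this basis alone. Compound 4 is expected to give an estimate of 80000 nM, within a range from 25000 nM to 150000 nM. The step of an at least 1.2-fold lower number from compound 1 to compound 4 (0.09 log units; that floor lies within the scatter) is thus expected to lie within the scatter rather than beyond it, with a fair chance that compound 4 too returns only a limit.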

Compound 4, half-maximal inhibitory concentration: 24000 nM
Compound 4: middle estimate off by 3.3-fold (0.52 log units), on the high side; the whole stated range lies above it.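

In this assay, ((chloromethyl)carbonyl)amino in place of hydroxy on an aromatic carbon, two atoms from the ring nitrogen, brings an at least 4.1-fold lower number from compound 1 to compound 4 (0.61 log units; beyond the scatter), which shows that a change at this position of the shared core can move the read-out to a measurable number. Compound 1 gives > 100000 nM, which is a limit and not a number, so this step marks only a floor and its true size cannot be read. Among the compounds shown, compound 4 alone gives a number rather than a limit: the limit of > 100000 nM in this assay, at which 3 of the 4 values shown sit.

The compounds shown leave open whether the chlorine is needed or whether the amide alone accounts for the step, a question that an acetylamino group, a bromoacetyl amino group or a longer chain at this position would address. Also open, going by these compounds, is how much the group of 7 heavy atoms contributes to the value of compound 4, which a plain hydrogen or a shorter chain in its place would test.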